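Swapping hydroxy for bromo next to the amide carbonyl

This account rests on a few compounds, and the source may have more. Where it says the series, first, only, none or still open, it means among the compounds named here.

Three compounds share one core and were tested in a functional assay on KYSE-450 cells (Homo sapiens) for inhibition, read by MTT assay, with a stated time of 48 h; a lower number here means a stronger inhibitor, a higher number a weaker inhibitor. Compound 1 `COc1ccc(CN(C(=O)C=C(C)C)c2cc(OC)c(OC)c(OC)c2)cc1O` gives 280 nM. Compound 2 `COc1ccc(CN(C(=O)CO)c2cc(OC)c(OC)c(OC)c2)cc1O` gives 370 nM, the second highest of the three numbers; its nearest neighbour is compound 1, and the step of a 1.3-fold higher number from compound 1 to compound 2 (0.12 log units; within the scatter) lies within the scatter, so the two cannot be told apart. Compound 3 `COc1ccc(CNc2cc(OC)c(OC)c(OC)c2)cc1F`, which lacks the amide carbonyl entirely and carries fluoro where the others carry hydroxy on the outer ring, gives 46200 nM, far from both.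

Compound 4 `COc1ccc(CN(C(=O)CBr)c2cc(OC)c(OC)c(OC)c2)cc1O` has not yet been measured. It differs from compound 2 in one place: bromo in place of hydroxy on a saturated chain carbon bound to a carbonyl carbon. Within the data shown here, no measured pair swaps hydroxy for bromo, so the only step that bears on this change is the one from compound 1 to compound 2, which altered the group on the carbonyl carbon and stayed within the scatter. On that basis, compound 4 is expected to give a number close to that of compound 2, with a step of a 1.2-fold lower number from compound 2 to compound 4 (0.09 log units; within the scatter) that need not exceed the scatter. The estimate for compound 4 in this assay is therefore 300 nM, with a range from 100 nM to 900 nM.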

Compound 4, half-maximal inhibitory concentration: 120 nM
The estimate for compound 4 lay 2.5-fold (0.40 log units) above the measured number; low and high end bracket the measured number.
By their numbers in this assay, from the lowest: compound 4; then compounds 1 and 2 (each within the scatter of the next); then compound 3.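

In this assay, the place on the saturated chain carbon bound to a carbonyl carbon now shows that it can move the number: the earlier change of group on the carbonyl carbon stayed within the scatter, whereas bromo in place of hydroxy gives a 3.1-fold lower number from compound 2 to compound 4 (0.49 log units; beyond the scatter) and this modest step lies beyond it. Bromomethyl in place of 2-methylprop-1-en-1-yl gives a step of similar kind (a 2.3-fold lower number from compound 1 to compound 4 (0.37 log units; beyond the scatter)), so compound 4 stands apart from both compound 1 and compound 2, which themselves cannot be told apart. Nothing in the data shown explains why the bromo compound gives the lower number.

A chloro group or an amine on the same carbon, or a longer chain ending in bromo, would show whether this lower number belongs to bromo itself or would appear with other groups at this place as well. As far as these compounds go, whether the same order of compounds holds on any other cell line, or under any other read-out, also remains open.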